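A few compounds are considered here, and "the series" means these few. Any claim that something is new, unique, unknown or untested is made for them only; others in the source may bear on it.

Measured compounds:
compound 1 `COc1ccc(-c2cc3ccccc3nc2/C=C/C(=O)c2ccccc2)cc1` — 6670 nM
compound 2 `COc1ccc(-c2cc3ccccc3nc2/C=C/C(=O)c2ccc(N)cc2)cc1` — 7400 nM

Among the compounds with values here, in a functional assay on NCI-H460 cells (Homo sapiens) for antiproliferative activity, read by XTT assay, with a stated time of 72 h (a lower number here means a stronger inhibitor, a higher number a weaker inhibitor), compound 2 gives 7400 nM, the higher of the two numbers measured so far. Its nearest neighbour is compound 1 with 6670 nM, and the step of a 1.1-fold higher number from compound 1 to compound 2 (0.05 log units; within the scatter) lies within the scatter, so the two compounds cannot be ordered.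

Compound 3 `COc1ccc(-c2cc3ccccc3nc2/C=C/C(=O)c2ccco2)cc1` is not yet measured. It differs from compound 2 in one place: furan-2-yl in place of 4-aminophenyl on a carbonyl carbon. Within the data shown here, no measured step in this assay bears directly on such an exchange of the whole aryl group on the carbonyl carbon. Among the measured compounds shown here, the only measured step, a 1.1-fold higher number from compound 1 to compound 2 (0.05 log units; within the scatter), concerns an amino added to the ring that here leaves, and it showed no movement beyond the scatter. The series therefore offers no evidence that changes at this end of the enone move the number, and no step beyond the scatter is expected in this assay.

For compound 3 the expected value in this assay is 7000 nM, with a range from 2500 nM to 20000 nM. The expected step of a 1.1-fold lower number from compound 2 to compound 3 (0.02 log units; within the scatter) is accordingly estimated to stay within the scatter.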

Compound 3, half-maximal inhibitory concentration: 6430 nM
Estimate against measurement, compound 3: 1.1-fold (0.04 log units) above; the range from low to high includes it.
By their numbers in this assay, from the lowest: compounds 3, 1 and 2 (each within the scatter of the next).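

In this assay, replacing the whole aryl group on the carbonyl carbon can now be read directly: furan-2-yl in place of 4-aminophenyl gives a 1.2-fold lower number from compound 2 to compound 3 (0.06 log units; within the scatter), and furan-2-yl in place of phenyl gives a 1.0-fold lower number from compound 1 to compound 3 (0.02 log units; within the scatter). The earlier step covered only an amino on the ring, whereas these steps change the ring itself, from a six-membered aromatic ring of carbon only to a five-membered aromatic ring with 1 hetero atom, and neither step leaves the scatter, so the three compounds cannot be ordered. No independent measurement is available to explain this flat reading at the carbonyl carbon.

The compounds shown leave open whether any group at this place can move the number beyond the scatter, for example a saturated cyclohexyl ring, a longer alkyl chain, or a phenyl ring carrying a carboxylic acid. They also leave open whether the shared core, rather than the group on the carbonyl carbon, governs the number, and whether the same flat reading would hold outside this assay.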